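Trading an Amide-Bearing Ring for a Plain Seven-Membered Ring

The source may hold more compounds than are shown below. What is called first, only, known or untested is meant among the compounds shown, and "the series" means these compounds.

Compound 1 `Cc1nn([C@H](C)c2ccc(Cl)cc2Cl)c2nc(N3CC[C@H](N4CCC[C@H]4C(N)=O)[C@H](C)C3)cnc12` gives 170 nM in a functional assay on cells for antagonist activity at C-C chemokine receptor type 4 (Homo sapiens), read by fluorescence and calcium flux, with stated times of 2.5 s and 45 s; a higher number here means a weaker inhibitor, a lower number a stronger inhibitor.
Compound 2 `Cc1nn([C@H](C)c2ccc(Cl)cc2Cl)c2nc(N3CC[C@H](N4CCC4)[C@H](C)C3)cnc12` gives 58 nM in this assay.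
Compound 3 `Cc1nn([C@H](C)c2ccc(Cl)cc2Cl)c2nc(N3CC[C@H](N4CCC[C@H]4CCC(N)=O)[C@H](C)C3)cnc12` gives 37 nM in this assay.

Compound 3 has the lowest number of the three measured compounds, but one of the two steps leading to it is small, a 1.6-fold lower number from compound 2 to compound 3 (0.20 log units; within the scatter), while the other is larger, a 4.6-fold lower number from compound 1 to compound 3 (0.66 log units; beyond the scatter). Compound 4 `Cc1nn([C@H](C)c2ccc(Cl)cc2Cl)c2nc(N3CC[C@H](N4CCCCCC4)[C@H](C)C3)cnc12` differs from compound 3 in one place: azepan-1-yl in place of 2-(2-carbamoylethyl)pyrrolidin-1-yl on a saturated ring carbon. Within the data shown here, two measured steps bear on this. Replacing the amide-bearing ring with a plain small ring gave a 2.9-fold lower number from compound 1 to compound 2 (0.47 log units; beyond the scatter), and the reverse kind of swap gave a 1.6-fold lower number from compound 2 to compound 3 (0.20 log units; within the scatter). A plain ring without the amide is therefore not expected to cost potency, and the expected step is a 1.4-fold higher number from compound 3 to compound 4 (0.13 log units; within the scatter). Compound 4 is estimated at 50 nM, in the range 20 nM to 150 nM.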

Compound 4, half-maximal inhibitory concentration: 23 nM
Beside the measured number, compound 4's estimate is 2.2-fold (0.34 log units) above it; measured number inside the range.
By their numbers in this assay, from the lowest: compounds 4, 3 and 2 (each within the scatter of the next, the first and the last beyond it); then compound 1.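

At this position on the six-membered ring, azepan-1-yl has no amide, and the step is a 1.6-fold lower number from compound 3 to compound 4 (0.21 log units; within the scatter) in this assay, so the number does not depend on the 2-carbamoylethyl chain of compound 3. The plain seven-membered ring also gives a 2.5-fold lower number from compound 2 to compound 4 (0.40 log units; beyond the scatter) and a 7.4-fold lower number from compound 1 to compound 4 (0.87 log units; beyond the scatter) in the same comparison of ring groups on this carbon. On these data alone, whether a diethylamino group or an azepan-1-yl ring carrying a carboxylic acid would keep such a number remains open. No measurement shown explains why these steps occur.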